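The compounds below may be only part of what the source reports. "The series", "measured", "known", "first", "only" and "open" are said of these compounds alone.

In an ADME assay on RAW264.7 cells (Mus musculus) for cytotoxicity, read by MTT assay, with a stated time of 48 h (a higher number here means that more compound is tolerated, a lower number that less compound is tolerated), compound 2 (`Fc1ccc(NC(=S)N/N=C\c2ccnc3ccccc23)cc1`) gives 45900 nM as the second highest of three numbers. It sits under compound 1 (`COc1ccc(NC(=S)N/N=C\c2ccnc3ccccc23)cc1`) at 101000 nM. It sits over compound 3 (`S=C(N/N=C\c1ccnc2ccccc12)Nc1cccc2ccccc12`) at 22600 nM on this read-out. Compound 4 (`S=C(N/N=C\c1ccnc2ccccc12)Nc1ccc(Br)cc1`) differs from compound 2 by bromo in place of fluoro on an aromatic carbon and carries bromo in place of fluoro on an aromatic carbon, para to a large group. Among the measured compounds shown here, the only measured step bearing on this is a 2.2-fold lower number from compound 1 to compound 2 (0.34 log units; beyond the scatter) and it is modest. For the measured compounds named here, no measured step involves bromo. A step no larger than that one is expected in this assay with the number going lower. The expected change is a 1.7-fold lower number from compound 2 to compound 4 (0.23 log units; within the scatter) by this estimate. The estimate for compound 4 is 27000 nM with an expected range from 13000 nM to 55000 nM in this read-out.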

Compound 4, half-maximal cytotoxic concentration: 53500 nM
For compound 4 the middle estimate is 2.0-fold (0.30 log units) below the measured one; measured number inside the range.
By their numbers in this assay, from the lowest: compound 3; then compounds 2, 4 and 1 (each within the scatter of the next, the first and the last beyond it).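

In this assay the change from 4-fluorophenyl to 4-bromophenyl gives a 1.2-fold higher number from compound 2 to compound 4 (0.07 log units; within the scatter) and so does not separate the two halogens at this position. Bromo in place of methoxy gives a 1.9-fold lower number from compound 1 to compound 4 (0.28 log units; within the scatter) and also stays within the scatter, whereas fluoro in place of methoxy gave a 2.2-fold lower number from compound 1 to compound 2 (0.34 log units; beyond the scatter) and remains the only step at this position beyond it. Across methoxy, fluoro and bromo, this position has therefore shown only a modest range. As far as these compounds go, whether an amine or a carboxylic acid here would move the number further remains open. No measured evidence speaks to the reason for these values.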